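From compound 1 to its ethoxycarbonyl relative

The source may hold more compounds than are shown below. What is called first, only, known or untested is meant among the compounds shown, and "the series" means these compounds.

Compound 1 `O=C1NC(c2ccccc2)CN1S(=O)(=O)c1ccc2c(c1)CCCN2`: > 20000 nM (a limit)
Compound 2 `COC(=O)N1CCCc2cc(S(=O)(=O)N3CC(c4ccccc4)NC3=O)ccc21`: > 20000 nM (a limit)

In a functional assay on K562 cells (Homo sapiens) for antiproliferative activity, read by MTT assay (on this read-out higher numbers stand for weaker inhibition and lower numbers for stronger inhibition), compound 1 gives > 20000 nM, which is a limit and not a number. Among the measured compounds shown here, compound 1 shares its standing with the only other measured compound: the limit of > 20000 nM in this assay, at which 2 of the 2 values shown sit. Compound 3 `CCOC(=O)N1CCCc2cc(S(=O)(=O)N3CC(c4ccccc4)NC3=O)ccc21` has ethoxycarbonyl in place of hydrogen on a nitrogen on an aromatic ring in a ring. The closest guide, with methoxycarbonyl at that place, is a step that the two limits leave unreadable from compound 1 to compound 2. No measured size is therefore available, and no clear step in either direction is expected in this assay. The expected step is a step that the limit leaves unreadable from compound 1 to compound 3. For compound 3 the estimated value is 25000 nM, within an expected range of 10000 nM to 60000 nM.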

Compound 3, half-maximal inhibitory concentration: > 20000 nM
Compound 3: only a limit was reported; the forecaster's own chance of this, stated with the estimate: 85%; the middle value lies beyond the limit too.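

No step can be read between compound 1, compound 2 and compound 3, because all three stop at the same limit: the limit of > 20000 nM in this assay, at which 3 of the 3 values shown sit.

The compounds shown leave open whether methoxycarbonyl or ethoxycarbonyl in place of hydrogen on that nitrogen changes the inhibition at all.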